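A few compounds are considered here, and "the series" means these few. Any claim that something is new, unique, unknown or untested is made for them only; others in the source may bear on it.

Of the compounds shown here, three sharing one core have been measured in an assay on isolated protein for inhibition of Rho-associated protein kinase 1 (Homo sapiens), read by scintillation counting, radiometric assay and 33P incorporation, with a stated time of 40 min, in the presence of a further agent that is not named here; on this read-out lower numbers stand for stronger inhibition and higher numbers for weaker inhibition. Compound 1 `Cc1ccc(C(=O)Nc2cccc(NC(=O)COc3ccc4c(=O)ccoc4c3)c2)cc1` gives 183 nM. Compound 2 `O=C(COc1ccc2c(=O)ccoc2c1)Nc1cccc(NC(=O)c2cccc([N+](=O)[O-])c2)c1` gives 528 nM, and compound 3 `CC(C)(C)c1cc(C(=O)Nc2cccc(NC(=O)COc3ccc4c(=O)ccoc4c3)c2)no1` gives 101 nM. Compound 3 has the lowest of the three numbers, but the step of a 1.8-fold lower number from compound 1 to compound 3 (0.26 log units; within the scatter) lies within the scatter, so compound 3 and compound 1 cannot be separated, while a 5.2-fold lower number from compound 2 to compound 3 (0.72 log units; beyond the scatter) and a 2.9-fold higher number from compound 1 to compound 2 (0.46 log units; beyond the scatter) show that the 3-nitrophenyl group of compound 2 goes with weaker inhibition than either of the other two groups.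

Compound 4 `Nc1ccc(C(=O)Nc2cccc(NC(=O)COc3ccc4c(=O)ccoc4c3)c2)cc1` has not yet been measured. It differs from compound 3 in one place: 4-aminophenyl in place of 5-(tert-butyl)-1,2-oxazol-3-yl on a carbonyl carbon. Among the measured compounds shown here, the steps that bear on this change are a 1.8-fold lower number from compound 1 to compound 3 (0.26 log units; within the scatter) and a 5.2-fold lower number from compound 2 to compound 3 (0.72 log units; beyond the scatter): exchanging one group on this carbonyl carbon for another has moved the number by a modest amount or not beyond the scatter. Compound 4 carries a six-membered ring of carbon only, as compound 1 does, so compound 4 is expected to land near compound 1, and the step of a 2.5-fold higher number from compound 3 to compound 4 (0.39 log units; beyond the scatter) is expected to be small. The estimate for compound 4 in this assay is 250 nM, with a range from 100 nM to 700 nM.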

Compound 4, half-maximal inhibitory concentration: 802 nM
Beside the measured number, compound 4's estimate is 3.2-fold (0.51 log units) below it; measured number above the stated range.
By their numbers in this assay, from the lowest: compounds 3 and 1 (each within the scatter of the next); then compounds 2 and 4 (each within the scatter of the next).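

The step of a 7.9-fold higher number from compound 3 to compound 4 (0.90 log units; beyond the scatter) is the widest yet at this carbonyl carbon, so the group here can move the number further than the first three compounds showed. Sharing a six-membered ring of carbon only does not settle the outcome: amino in place of methyl on an aromatic carbon gives a 4.4-fold higher number from compound 1 to compound 4 (0.64 log units; beyond the scatter), while a 1.5-fold higher number from compound 2 to compound 4 (0.18 log units; within the scatter) leaves the 4-aminophenyl and 3-nitrophenyl groups inseparable here. Nothing available explains why these numbers shift.

As far as these compounds go, it remains open where other groups on that same aromatic carbon, such as methoxy, fluorine or dimethylamino, would fall relative to methyl and amino. From the compounds shown here alone, it is also open how much of the 5-(tert-butyl)-1,2-oxazol-3-yl group's standing depends on its tert-butyl, which a methyl or cyclopropyl group in that place could test.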